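The source may hold more compounds than are shown below. What is called first, only, known or untested is meant among the compounds shown, and "the series" means these compounds.

Series notes, cytotoxicity. In a functional assay on HCT-8 cells (Homo sapiens) for cytotoxicity (a lower number here means that less compound is needed, a higher number that more compound is needed for the effect), compound 1 `c1ccc(COc2cc(-c3ccccc3)nc3ccccc23)cc1` gives > 10 ug/mL. That reading is a limit of the assay and not a number, so compound 1 has no exact position on the scale. In this assay, compound 2 `COc1ccc2nc(-c3ccccc3)cc(O)c2c1` gives a true number, 1 ug/mL.

Compound 3 `CCCCOc1cc(-c2ccccc2)nc2ccccc12` keeps the core of compound 1 and carries propyl in place of phenyl on a saturated chain carbon bound to an oxygen on an aromatic ring. The same change reads as benzyloxy to butoxy.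

Going by the values given here, no measured step covers this change, so its size in this assay cannot be calibrated. The expectation rests on compound 1, whose reading of > 10 ug/mL is a limit. No shift beyond the scatter is expected, and another limit reading is thought more likely than not. The expected size of the step of a number no higher from compound 1 to compound 3 (the limit leaves the size open) is therefore small, with no direction favoured. For compound 3 the estimated value is 10 ug/mL, with an expected range of 3 ug/mL to 30 ug/mL.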

Compound 3, half-maximal effective concentration: > 10 ug/mL
Compound 3: only a limit was reported (the forecaster's own chance of this, stated with the estimate: 65%); the middle value lies on the limit itself.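

In this assay compound 1 and compound 3 both stand at a limit of the assay and not at a number, so no step between them can be read: the limit of > 10 ug/mL in this assay, at which 2 of the 3 values shown sit.

The compounds shown leave open how far apart compound 1 and compound 3 lie on the scale, and so whether butoxy in place of benzyloxy changes the reading at all.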